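Replacing the side chain of compound 3

The source may hold more compounds than are shown below. What is called first, only, known or untested is meant among the compounds shown, and "the series" means these compounds.

In a functional assay on V79 cells (Cricetulus griseus) for cytotoxicity, read by colony formation (a higher number here means a weaker inhibitor, a lower number a stronger inhibitor), compound 1 `CCNCC1CCN(c2c(F)cc3c(=O)c(C(=O)O)cn(C4CC4)c3c2F)C1` gives 11 ug/mL; 11 ug/mL; 11 ug/mL; 11 ug/mL (4 entries) and compound 2 `CCNCC1CCN(c2c(F)cc3c(=O)c(C(=O)O)cn(C4CC4)c3c2Cl)C1` gives 11 ug/mL; 11 ug/mL; < 11 ug/mL (3 entries). The entries for compound 2, one of which is a limit, read (the several entries of compound 2 in this assay, 11 ug/mL; 11 ug/mL; < 11 ug/mL (3 entries)). Compound 3 `CCNCC1CCN(c2c(F)cc3c(=O)c(C(=O)O)cn(-c4ccc(F)cc4F)c3c2Cl)C1` stands at 130 ug/mL, a higher number than those of compound 1 and compound 2. Compound 4 `CC1CN(c2c(F)cc3c(=O)c(C(=O)O)cn(-c4ccc(F)cc4F)c3c2Cl)CCN1` has 3-methylpiperazin-1-yl in place of 3-((ethylamino)methyl)pyrrolidin-1-yl on an aromatic carbon. Within the data shown here, no measured pair shows this exchange, so the expectation rests on compound 3 at 130 ug/mL. A small upward move in this assay is expected, probably no larger than the scatter, and the expected change is a 1.2-fold higher number from compound 3 to compound 4 (0.09 log units; within the scatter). For compound 4 the estimate is 160 ug/mL, with an expected range from 60 ug/mL to 400 ug/mL.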

Compound 4, half-maximal inhibitory concentration: > 500 ug/mL
Compound 4: only a limit was reported; the forecaster's own chance of this, stated with the estimate: 25%; middle value at least 3.1-fold (0.49 log units) away from the limit.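

In this assay, the amine on this aromatic carbon, ortho to the chloro and fluoro groups, proves able to move the read-out: 3-methylpiperazin-1-yl in place of 3-((ethylamino)methyl)pyrrolidin-1-yl gives an at least 3.8-fold higher number from compound 3 to compound 4 (0.58 log units; beyond the scatter). Compound 1, compound 2 and compound 3 all carry the same side chain, so they could not show this. For compound 4 the reading is a limit, not a number: the limit of > 500 ug/mL in this assay, at which 1 of the 4 values shown sits.

From the compounds shown here alone, whether the step follows the change of ring or the methyl group stays open. Going by these compounds, a plain piperazine without the methyl would separate the two, and how far the step extends also remains unknown.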